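This account rests on a few compounds, and the source may have more. Where it says the series, first, only, none or still open, it means among the compounds named here.

Measured compounds:
Compound 1 `COc1ccc(OC)c(-c2cc(-c3ccc(Cl)cc3)nn2-c2ccccc2)c1` gives 84300 nM in a functional assay on cells (Cancer cell lines, Homo sapiens) for cytotoxicity, read by sulforhodamine B assay, with a stated time of 48 h; a lower number here means a stronger inhibitor of growth, a higher number a weaker inhibitor of growth.
Compound 2 `Oc1ccc(O)c(-c2cc(-c3ccccc3)nn2-c2ccccc2)c1` gives 71200 nM in this assay.

Compound 2 holds the lowest of the two numbers, yet compound 1 sits close to it, within the scatter, so the two cannot be ranked against each other. Compound 3 `Oc1ccc(O)c(-c2cc(-c3ccc(Cl)cc3)nn2-c2ccccc2)c1` is built from compound 2 by one change, (chloro in place of hydrogen on an aromatic carbon), on an aromatic carbon of a six-membered aromatic ring of carbon only. For the measured compounds named here, no measured pair isolates this change, so the expected step in this assay rests on the two numbers alone, which suggest that neither the chloro group nor the hydroxy-for-methoxy exchange moves the growth inhibition far. For compound 3 the expected step of a 1.2-fold lower number from compound 2 to compound 3 (0.07 log units; within the scatter) is therefore small, if anything a slight lowering, and not beyond the scatter. Compound 3 is estimated at 60000 nM, with a range from 25000 nM to 140000 nM.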

Compound 3, concentration for total growth inhibition: 34600 nM
The estimate for compound 3 lay 1.7-fold (0.24 log units) above the measured number; the measured number falls inside the stated range.
By their numbers in this assay, from the lowest: compound 3; then compounds 2 and 1 (each within the scatter of the next).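

Chloro in place of hydrogen on an aromatic carbon, para to a large group, gives a 2.1-fold lower number from compound 2 to compound 3 (0.31 log units; beyond the scatter) in this assay. For the compounds shown here, this is the first single change that can be read, and it shows that this position responds to substitution, though only modestly, with the two hydroxy groups of compound 2 kept in place. Nothing available here accounts for the step.

As far as these compounds go, whether the chloro group gives a similar step when methoxy groups replace the hydroxy groups stays open, as compound 1 has no partner lacking the chloro group. Also open, from the compounds shown here alone, is how this position would respond to a group other than chloro, such as bromo, an amine or a carboxylic acid, or whether any such group would lower the number further.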